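Moving from dimethylsulfamoyl to (dimethylamino)methyl on the side chain

This account rests on a few compounds, and the source may have more. Where it says the series, first, only, none or still open, it means among the compounds named here.

In a functional assay on the whole organism with Rattus norvegicus as the target (a higher number here means that more compound is needed for the effect, a lower number that less compound is needed), compound 1 `C[Si](C)(C)c1ccc2nc(N)sc2c1` gives 5 mg/kg. Compound 2 `CN(C)S(=O)(=O)CCn1c(=N)sc2cc(OC(F)(F)F)ccc21` is known only by a limit of the assay, not a number: in this assay compound 2 gives > 10 mg/kg, which is the limit of > 10 mg/kg in this assay, at which 1 of the 2 values shown sits. Compound 3 `CN(C)CCCn1c(=N)sc2cc(OC(F)(F)F)ccc21` differs from compound 2 by (dimethylamino)methyl in place of dimethylsulfamoyl on a saturated chain carbon, two bonds along the chain from an aromatic nitrogen. Going by the values given here, because compound 2 rests on (the limit of > 10 mg/kg in this assay, at which 1 of the 2 values shown sits), no measured step can anchor the expectation, and the writer expects the dose to fall clearly beyond the scatter. Compound 3 is expected to give 5 mg/kg, within a range of 1.5 mg/kg to 20 mg/kg. The step expected is an at least 2.0-fold lower number from compound 2 to compound 3 (0.30 log units; that floor lies within the scatter).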

Compound 3, dose for half-maximal effect: 9 mg/kg
Compound 3: middle estimate off by 1.8-fold (0.26 log units), on the low side; the range from low to high includes it.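

Compound 3 places the side chain carrying (dimethylamino)methyl in place of dimethylsulfamoyl on a measured number in this assay and shows that this change keeps a dose that can be read, whereas compound 2 holds only a limit. The change reads as an at least 1.1-fold lower number from compound 2 to compound 3 (0.04 log units; that floor lies within the scatter) and so does not establish a difference beyond the scatter. The true size of the step stays unknown, and only this floor can be given, because compound 2 rests on a limit: the limit of > 10 mg/kg in this assay, at which 1 of the 3 values shown sits.

From the compounds shown here alone, whether a carboxylic acid or a longer chain at this place would lower the dose remains open.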